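The source may hold more compounds than are shown below. What is called first, only, known or untested is meant among the compounds shown, and "the series" means these compounds.

Measured so far in a functional assay on BXPC-3 cells (Homo sapiens) for antiproliferative activity, read by MTT assay, with a stated time of 24 h; on this read-out lower numbers stand for stronger inhibition and higher numbers for weaker inhibition:
- Compound 1 `CCn1c(C(=O)N[C@@H](CC(=O)OC)C(=O)OC)ccc1C(CC)(CC)c1ccc(OCS(=O)(=O)c2ccccc2)c(C)c1`: > 50000 nM (a limit)
- Compound 2 `CCN(CC)CCNC(=O)c1cc(C(CC)(CC)c2ccc(OCSC)c(C)c2)cn1CC`: 4110 nM

The value for compound 1 is a limit of the assay and not a number. For the measured compounds named here, that leaves compound 2 with the only numerical value in the set, at 4110 nM.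

Compound 3 `CCN(CC)CCNC(=O)c1cc(C(CC)(CC)c2ccc(OCSc3ccccc3)c(C)c2)cn1CC` differs from compound 2 in one place, with phenyl in place of methyl on a sulfur. Methylsulfanyl thus becomes phenylsulfanyl. Going by the values given here, no measured pair shows this change, so the expectation for this assay is only a small shift toward stronger inhibition, probably not beyond the usual scatter. The expected change is a 1.6-fold lower number from compound 2 to compound 3 (0.22 log units; within the scatter). For compound 3 the estimate is 2500 nM, with an expected range of 800 nM to 8000 nM.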

Compound 3, half-maximal inhibitory concentration in the BXPC-3 assay: 5370 nM
Compound 3: middle estimate off by 2.1-fold (0.33 log units), on the low side, and the stated range covers the measured number.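

On the sulfur whose other neighbour is a saturated chain carbon, replacing methylsulfanyl with phenylsulfanyl leaves the BXPC-3 assay within the scatter, with a 1.3-fold higher number from compound 2 to compound 3 (0.12 log units; within the scatter). This position therefore accepts a six-membered aromatic ring of carbon in place of a single carbon with no step beyond the scatter in that read-out. In a physicochemical assay for solubility, read by HPLC, at pH 7.4 (a higher number here means a more soluble compound, a lower number a less soluble compound), however, the same change is far from silent: compound 2 gives 198 ug/mL and compound 3 gives 0.6 ug/mL. The drop is large: the measured solubility of compound 2, 198 ug/mL, and of compound 3, 0.6 ug/mL, a 330-fold lower number (2.52 log units; beyond the scatter)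

From the compounds shown here alone, it remains open whether an amine or a carboxylic acid on the phenyl, or a longer chain on the sulfur, would hold the BXPC-3 assay while keeping the physicochemical assay nearer to compound 2. In the BXPC-3 assay compound 1 gives > 50000 nM, a limit and not a number, and it differs from compound 2 in more than one place, so it cannot settle this.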